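The source may report more compounds than this note shows. Statements on the series, on what has been measured and on what is new or still open speak of the compounds shown alone.

Three compounds built on one shared core have been run in an ADME assay on 2209-23 cells (Homo sapiens) for cytotoxicity, read by WST assay; on this read-out higher numbers stand for lower toxicity in this test and lower numbers for higher toxicity in this test. Compound 1 `Nc1ccc2c(c1)S(=O)(=O)C=C(c1c(O)c3cc(F)ccc3n(Cc3ccc(F)cc3)c1=O)N2` gives > 50000 nM, which is a limit of the assay and not a number. Compound 2 `COc1ccc2c(c1)c(O)c(C1=CS(=O)(=O)c3cc(NS(C)(=O)=O)ccc3N1)c(=O)n2Cc1ccc(F)cc1` gives > 50000 nM, again only a limit. Compound 3 `CS(=O)(=O)Nc1ccc2c(c1)S(=O)(=O)C=C(c1c(O)c3cc(F)ccc3n(Cc3ccc(F)c(F)c3)c1=O)N2` gives > 50000 nM, once more a limit, so compound 3 stands at the limit of > 50000 nM in this assay, at which 3 of the 3 values shown sit. Compound 4 `COC(C)(C)CCn1c(=O)c(C2=CS(=O)(=O)c3cc(NS(C)(=O)=O)ccc3N2)c(O)c2cc(F)ccc21` is not yet measured and differs from compound 3 by 2-methoxy-2-methylpropyl in place of 3,4-difluorophenyl on a saturated chain carbon bound to an aromatic nitrogen. Among the compounds with values here, no step between measured compounds is known, so the expectation is a change within the usual scatter, neither toward higher nor lower toxicity. Compound 4 is therefore expected to give 50000 nM in this assay, within 25000 nM to 100000 nM. The expected step is a number no higher from compound 3 to compound 4 (the limit leaves the size open).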

Compound 4, half-maximal cytotoxic concentration: > 50000 nM
Compound 4 was reported as a limit; the forecaster's own chance of this, stated with the estimate: 85%; the middle value sits exactly at the limit.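

In this assay, within the data shown here, compound 3 and compound 4 are both reported only as limits, so no step between them can be read: the limit of > 50000 nM in this assay, at which 4 of the 4 values shown sit. As far as these compounds go, whether 3-methoxy-3-methylbutyl in place of 3,4-difluorobenzyl changes toxicity at all stays open.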